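A few compounds are considered here, and "the series" means these few. Any claim that something is new, unique, unknown or untested is made for them only; others in the source may bear on it.

The measured compounds:

Compound 1, `COC(=O)C1=Cc2ccc(OC)cc2OC1c1cc(OC)c(OC)c(OC)c1`, gives 13800 nM in a functional assay for inhibition of nuclear factor NF-kappa-B complex (Homo sapiens); a lower number here means a stronger inhibitor, a higher number a weaker inhibitor.
Compound 2, `COc1ccc2c(c1)OC(c1cc(OC)c(OC)c(OC)c1)C(C(=O)O)=C2`, reaches only the limit > 50000 nM in this assay.
Compound 3, `COc1ccc2c(c1)OC(c1cc(OC)c(OC)c(OC)c1)C=C2`, gives 17700 nM in this assay.

Compound 3 holds the higher of the two plain numbers, but the step of a 1.3-fold higher number from compound 1 to compound 3 (0.11 log units; within the scatter) lies within the scatter, so compound 1 and compound 3 cannot be told apart. The value of compound 2 is a limit of the assay, not a number (the limit of > 50000 nM in this assay, at which 1 of the 3 values shown sits).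

Compound 4, `CNC(=O)C1=Cc2ccc(OC)cc2OC1c1cc(OC)c(OC)c(OC)c1`, differs from compound 3 in one place: methylcarbamoyl in place of hydrogen on a double-bonded ring carbon. Within the data shown here, two measured steps bear on this position. Removing methoxycarbonyl there changed little, a 1.3-fold higher number from compound 1 to compound 3 (0.11 log units; within the scatter), whereas removing carboxy there gave an at least 2.8-fold lower number from compound 2 to compound 3 (0.45 log units; beyond the scatter). Methylcarbamoyl is a third group at the same ring carbon; of the two precedents, the ester is the closer comparison, so a small step is expected in this assay, with the acid as a warning that a weaker number is possible. Compound 4 is therefore estimated at 16000 nM, within 6000 nM to 45000 nM, an expected step of a 1.1-fold lower number from compound 3 to compound 4 (0.04 log units; within the scatter).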

Compound 4, half-maximal inhibitory concentration: > 50000 nM
Compound 4: a limit, no number (the forecaster's own chance of this, stated with the estimate: 20%); middle value at least 3.1-fold (0.49 log units) from the limit.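

Compound 4 gives only a limit in this assay, not a number, and compound 2 stands at that same limit: the limit of > 50000 nM in this assay, at which 2 of the 4 values shown sit.

So the group on this double-bonded ring carbon does matter: methylcarbamoyl gives an at least 2.8-fold higher number from compound 3 to compound 4 (0.45 log units; beyond the scatter), and swapping only the ester's methoxy for methylamino gives an at least 3.6-fold higher number from compound 1 to compound 4 (0.55 log units; beyond the scatter). The earlier tolerance therefore belongs to the methyl ester, not to every carbonyl group at this carbon. The step from compound 2 to compound 4 cannot be read, as both values are limits.

Still open, on these data alone, is which part of methylcarbamoyl matters, the amide hydrogen or the methyl group. An unsubstituted carbamoyl, a dimethylcarbamoyl or an ethyl ester at this carbon would help separate these and show how far the tolerance extends.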